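The source may hold more compounds than are shown below. What is called first, only, known or untested is meant among the compounds shown, and "the series" means these compounds.

In an assay on isolated protein for inhibition of 3',5'-cyclic-AMP phosphodiesterase 4A (Cavia porcellus), read by cAMP accumulation, tested at 50 uM (on this read-out lower numbers stand for a weaker effect and higher numbers for a stronger effect at the one concentration tested), compound 3 `CC(C)(C)C(=O)c1cc2c([nH]c1=O)CCCC2=O` gives 6.6%, the highest of the three numbers, though it lies within the scatter of compound 2 `O=C1CC(c2ccccc2)Cc2[nH]c(=O)c(S(=O)(=O)c3ccccc3)cc21` at 5.7% and of compound 1 `O=C1CC(c2ccccc2)Cc2[nH]c(=O)c(C(=O)c3ccccc3)cc21` at 1.7%. Compound 4 `CC(C)(C)C(=O)c1cc2c([nH]c1=O)CC(c1ccccc1)CC2=O` differs from compound 3 by phenyl in place of hydrogen on a saturated ring carbon. For the measured compounds named here, the one measured step, a number 4 percentage points higher from compound 1 to compound 2 (within the scatter), concerns another change and does not bear on this one; no measured pair differs by a phenyl in place of hydrogen on a saturated ring carbon. Compounds 1 and 2 already carry that phenyl, and their numbers sit with that of compound 3. Compound 4 is therefore expected to show a number 1.6 percentage points lower from compound 3 to compound 4 (within the scatter), nothing beyond the scatter. For compound 4 the estimated value is 5%, within 0% and 15%.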

Compound 4, a percentage reported as inhibition, at one concentration (the size of the read-out at that concentration, not a potency): 3.3%
Compound 4: middle estimate off by 1.7 percentage points, on the high side; the measured number falls inside the stated range.
By their numbers in this assay, from the lowest: compounds 1, 4, 2 and 3 (each within the scatter of the next).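

In this assay, phenyl in place of hydrogen on a saturated ring carbon now has a measured pair of its own, and the change does not move the number beyond the scatter (a number 3.3 percentage points lower from compound 3 to compound 4 (within the scatter)). Neither do the two other changes that compound 4 completes, (tert-butyl)carbonyl in place of phenylsulfonyl on an aromatic carbon (a number 2.4 percentage points lower from compound 2 to compound 4 (within the scatter)) and tert-butyl in place of phenyl on a carbonyl carbon (a number 1.6 percentage points higher from compound 1 to compound 4 (within the scatter)). No measurement on hand speaks to what lies behind these numbers. 

Going by these compounds, whether an amine or a carboxylic acid in place of that phenyl would move the number beyond the scatter stays open. So does how any of these compounds would read at another concentration.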